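Piperidine Nitrogen Substituent Change in the Amidoxime Series

This account rests on a few compounds, and the source may have more. Where it says the series, first, only, none or still open, it means among the compounds named here.

Among the measured compounds shown here, compound 1 `O=C(/C(=N/O)Nc1ccc(F)c(Br)c1)C1CCN(c2ccccc2)CC1` stands at the higher end of the two numbers so far: in an assay on tissue (HeLa cells) for inhibition of Indoleamine 2,3-dioxygenase 1 (Homo sapiens), with a stated time of 48 h (a higher number here means a weaker inhibitor, a lower number a stronger inhibitor), compound 1 gives 1020 nM, whereas compound 2 `O=C(/C(=N/O)Nc1ccc(F)c(Br)c1)C1CCCCC1` gives 63 nM, a gap well beyond the scatter. Compound 3 `O=C(/C(=N/O)Nc1ccc(F)c(Br)c1)C1CCN(C(=O)Nc2ccccc2)CC1` differs from compound 1 by phenylcarbamoyl in place of phenyl on an amine nitrogen in a ring. For the measured compounds named here, no measured pair maps this particular change, so its direction rests on judgement alone. Compound 3 is expected to move only modestly, if at all, with a step estimated at a 1.7-fold lower number from compound 1 to compound 3 (0.23 log units; within the scatter). The estimate for compound 3 is 600 nM, with a range from 150 nM to 2500 nM.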

Compound 3, half-maximal inhibitory concentration: 54 nM
For compound 3 the middle estimate is 11-fold (1.05 log units) above the measured one; measured number below the stated range.
By their numbers in this assay, from the lowest: compounds 3 and 2 (each within the scatter of the next); then compound 1.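

On the amine nitrogen in the six-membered ring, phenylcarbamoyl in place of phenyl gives a large gain in this assay, a 19-fold lower number from compound 1 to compound 3 (1.28 log units; beyond the scatter). The position therefore responds strongly to this change, even though a six-membered aromatic ring of carbon only is present on both sides of it. Nothing measured here accounts for the size of this step.

The compounds shown leave open whether the carbonyl alone would suffice, as a benzoyl group on the same nitrogen would test, or whether the amide hydrogen also matters. On these data alone, whether the phenyl ring can give way to a methylcarbamoyl group also remains open.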